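The source may hold more compounds than are shown below. What is called first, only, known or untested is meant among the compounds shown, and "the series" means these compounds.

Among the compounds with values here, compound 1 `COc1cn2ncc(-c3ccnc(OC(C)(C)C)c3)c2nc1-c1cnn(C)c1` and compound 2 `COc1cc(-c2cnn3cc(OC)c(C4CCOC4)nc23)ccn1` share the core and differ in several places, so no single step is drawn between them. In an ADME assay on microsomes from liver (Rattus norvegicus) for metabolic stability, with a stated time of 60 min, tested at 1 uM (on this read-out higher numbers stand for a more stable compound and lower numbers for a less stable compound), compound 1 gives 61%, while compound 2 gives 34%, the lower of the two numbers and beyond the scatter from compound 1. Compound 3 `CNc1nc2c(-c3ccnc(OC)c3)cnn2cc1OC` carries methylamino in place of oxolan-3-yl on an aromatic carbon relative to compound 2. Within the data shown here, no measured pair shows this change, so its effect in this assay is open; a modest rise is expected, roughly a number 11 percentage points higher from compound 2 to compound 3 (beyond the scatter), but a step within the scatter is also plausible. Compound 3 is estimated at 45%, from 25% to 70%.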

Compound 3, percent of the compound remaining: 74%
Beside the measured number, compound 3's estimate is 29 percentage points below it; measured number above the stated range.
By their numbers in this assay, from the lowest: compound 2; then compound 1; then compound 3.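

Methylamino in place of oxolan-3-yl on an aromatic carbon gives a number 40 percentage points higher from compound 2 to compound 3 (beyond the scatter) in this assay and is the first one-place step in the series. This position is therefore sensitive to the group it carries, and a change here alone can move the read-out by a large step. Nothing measured bears on the reason for the step. From the compounds shown here alone, whether dimethylamino, ethylamino or a methoxy group at this carbon would match methylamino stays open. The step rests on one pair, so its transfer to other substituents on the shared core is also unknown.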